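A few compounds are considered here, and "the series" means these few. Any claim that something is new, unique, unknown or untested is made for them only; others in the source may bear on it.

Compound 1, `Cc1nn(-c2ncnc3nc[nH]c23)c2c1C(OCCc1ccccc1)CC(=O)N2`, gives 40 nM in a functional assay on HEK293 cells for agonist activity at G-protein coupled receptor 39 (Homo sapiens), read by scintillation proximity assay and inositol phosphate accumulation, with a stated time of 75 min; a higher number here means that more compound is needed for the effect, a lower number that less compound is needed. Compound 2, `Cc1nn(-c2ncnc3nc[nH]c23)c2c1C(OC(=O)c1ccc(F)cc1)CC(=O)N2`, gives 245 nM.

Within the data shown here, compound 2 stands at the higher of the two numbers; its only neighbour is compound 1, the gap being a 6.1-fold higher number from compound 1 to compound 2 (0.79 log units; beyond the scatter). Compound 3, `Cc1nn(-c2ncnc3nc[nH]c23)c2c1C(NC(=O)Cc1cccs1)CC(=O)N2`, comes from compound 2 by a single change: (((thiophen-2-yl)methyl)carbonyl)amino in place of ((4-fluorophenyl)carbonyl)oxy on a saturated ring carbon. Among the measured compounds shown here, the one measured step, which also altered the group on that oxygen, is the sole guide, and it was modest. A return toward the lower number of compound 1 seems plausible, though the new group resembles neither. Compound 3 is expected to give 110 nM, between 30 nM and 450 nM. That estimate means a 2.2-fold lower number from compound 2 to compound 3 (0.35 log units; beyond the scatter).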

Compound 3, half-maximal effective concentration: 244 nM
Beside the measured number, compound 3's estimate is 2.2-fold (0.35 log units) below it, within the range that was stated.
By their numbers in this assay, from the lowest: compound 1; then compounds 3 and 2 (each within the scatter of the next).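

With (((thiophen-2-yl)methyl)carbonyl)amino and ((4-fluorophenyl)carbonyl)oxy on this saturated ring carbon, this assay shows a 1.0-fold lower number from compound 2 to compound 3 (0.00 log units; within the scatter) and so does not separate the two groups, although they differ in linking atom and aromatic ring. Phenethyloxy still stands apart from both groups, with a 6.1-fold higher number from compound 1 to compound 3 (0.79 log units; beyond the scatter) as the second new step. No supporting data explain this result. The compounds shown leave open whether the ether oxygen or the phenethyl chain goes with the lower number of compound 1, and how a benzyloxy group or a plain amine would read at this carbon.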